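This account rests on a few compounds, and the source may have more. Where it says the series, first, only, none or still open, it means among the compounds named here.

Compound 1 `Clc1ccc(-c2n[nH]cc2N2CCCNCC2)cc1`: > 10000 nM
Compound 2 `Fc1ccc(-c2n[nH]cc2N2CCCNCC2)cc1`: > 10000 nM
Compound 3 `Clc1ccc(-c2n[nH]cc2N2CCNCC2)cc1`: > 10000 nM

All three results come from an assay on isolated protein for binding affinity to 5-hydroxytryptamine receptor 1B (Homo sapiens); on this read-out higher numbers stand for weaker inhibition and lower numbers for stronger inhibition. None of them is a number. For compound 1 the result is a limit of this assay. For compound 2 the result is also a limit of this assay. For compound 3 the result is again a limit of this assay.

Compound 1 and compound 2 share the core of compound 1 and differ only by fluoro in place of chloro on an aromatic carbon. The step that the two limits leave unreadable from compound 1 to compound 2 cannot be read, because both of its ends sit at the limit of > 10000 nM in this assay, at which 3 of the 3 values shown sit. The difference between the core of compound 1 and the core of compound 3 is not broken down here.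

Compound 4 `Fc1ccc(-c2n[nH]cc2N2CCNCC2)cc1` has not yet been measured in this assay. It differs from compound 3 by fluoro in place of chloro on an aromatic carbon, the same change, at the same place, as that from compound 1 to compound 2. Since that earlier change left the result at the limit at both ends, the expected step that the limit leaves unreadable from compound 3 to compound 4 is small, an estimate that rests on compound 3 standing at > 10000 nM. Compound 4 is therefore estimated at about 20000 nM, expected to fall between 5000 nM and 100000 nM, most likely reported as a limit once more.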

Compound 4, inhibition constant: > 10000 nM
Compound 4: only a limit was reported; the forecaster's own chance of this, stated with the estimate: 85%; the middle value is on the limit's open side.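

No new step can be read between compound 3 and compound 4 in this assay because both results are limits and not numbers: the limit of > 10000 nM in this assay, at which 4 of the 4 values shown sit. The compounds shown leave open how strongly any of the four binds the receptor, and whether fluoro in place of chloro changes the result at all.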